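Working notes: 4-nitrobenzyl to 3-bromobenzyl on the shared core

The source may report more compounds than this note shows. Statements on the series, on what has been measured and on what is new or still open speak of the compounds shown alone.

Values from an ADME assay on GES1 cells (Homo sapiens) for inhibition, read by MTT assay, with a stated time of 72 h (a higher number here means a weaker inhibitor, a lower number a stronger inhibitor), follow
Compound 1 `Cc1cc(Nc2cc(-c3ccccc3)[nH]n2)n2nc(SCc3ccc([N+](=O)[O-])cc3)nc2n1` gives 43600 nM as a number
Compound 2 `Cc1cc(Nc2ccn(Cc3ccccc3)n2)n2nc(SCc3ccc(Br)cc3)nc2n1` gives 44400 nM as a number
Compound 3 `CCCCCc1c(C)nc2nc(SCc3ccc(Cl)cc3)nn2c1Nc1cc(-c2ccccc2)[nH]n1` gives > 50000 nM as a limit of the assay, not a number

Going by the values given here, compound 1 and compound 2 supply the only two numbers in the set. Compound 1 at 43600 nM and compound 2 at 44400 nM lie within the scatter of each other. The entry for compound 3 is a limit and offers no number for comparison.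

The next compound to be measured is compound 4 `Cc1cc(Nc2cc(-c3ccccc3)[nH]n2)n2nc(SCc3cccc(Br)c3)nc2n1` and it keeps the core of compound 1. It carries 3-bromophenyl in place of 4-nitrophenyl on a saturated chain carbon bound to a sulfur, as 3-bromophenyl in place of 4-nitrophenyl on a saturated chain carbon bound to a sulfur sets out in full.

Among the compounds with values here, no measured pair differs in one place only, so the size of this change in this assay can only be estimated. Within the data shown here, with compound 1 at 43600 nM and compound 2 at 44400 nM as the only numbers available, no step beyond the scatter is expected in either direction. The estimated step of a 1.0-fold lower number from compound 1 to compound 4 (0.02 log units; within the scatter) stays within the scatter. Compound 4 could also be reported only as a limit, given the limit of > 50000 nM in this assay, at which 1 of the 3 values shown sits, in this small set. Compound 4 is expected at 42000 nM within an estimated range of 24000 nM to 50000 nM when measured.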

Compound 4, half-maximal inhibitory concentration: > 50000 nM
Compound 4 was reported as a limit; the forecaster's own chance of this, stated with the estimate: 30%; at least 1.1-fold (0.07 log units) between middle value and limit.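

In this assay, going by these compounds alone, the change from 4-nitrobenzyl to 3-bromobenzyl gives the first step that can be read at a single place, with the shared core unchanged: an at least 1.1-fold higher number from compound 1 to compound 4 (0.05 log units; that floor lies within the scatter). On these data alone, compound 4 gives > 50000 nM, which is a limit of the assay and not a number, so the real size of this step is unknown and its printed floor does not separate compound 4 from compound 1. The result therefore shows only that, on a saturated chain carbon bound to a sulfur, 3-bromophenyl in place of 4-nitrophenyl leaves compound 4 at the limit, where compound 3 also sits: the limit of > 50000 nM in this assay, at which 2 of the 4 values shown sit.

The step changes both the group on the phenyl ring and its location, so the compounds shown do not tell these two parts of the change apart. As far as these compounds go, how a 4-aminobenzyl group, a benzyl group carrying a carboxylic acid, or a longer chain in place of the benzyl group would read at this position remains open, as does any number for compound 4 beyond the limit.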